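A few compounds are considered here, and "the series" means these few. Any claim that something is new, unique, unknown or untested is made for them only; others in the source may bear on it.

Series notes. The shared core is carried by compound 1 `O=C(Nc1c(C(O)(C(F)(F)F)C(F)(F)F)ccc2ccccc12)C1CC1`, compound 2 `O=C(Nc1c(C(O)(C(F)(F)F)C(F)(F)F)ccc2ccccc12)c1ccccc1Cl` and compound 3 `O=C(Nc1c(C(O)(C(F)(F)F)C(F)(F)F)ccc2ccccc12)c1cccc(Br)c1`. In an assay on LtK cells with ATP-sensitive inward rectifier potassium channel 11 (Homo sapiens) as the target (on this read-out higher numbers stand for an effect only at larger amounts of compound and lower numbers for an effect already at smaller amounts), compound 1 gives 751 nM, compound 2 gives 2040 nM and compound 3 gives 80 nM. Compound 3 holds the lowest number of the three: the nearest is compound 1, with a 9.4-fold lower number from compound 1 to compound 3 (0.97 log units; beyond the scatter), and the furthest is compound 2, with a 26-fold lower number from compound 2 to compound 3 (1.41 log units; beyond the scatter). The next compound, compound 4 `O=C(Nc1c(C(O)(C(F)(F)F)C(F)(F)F)ccc2ccccc12)c1cc(Cl)cc(Cl)c1`, differs from compound 3 in one place: 3,5-dichlorophenyl in place of 3-bromophenyl on a carbonyl carbon. For the measured compounds named here, no measured step covers a second ring halogen; the steps that touch the group on the carbonyl carbon are a 2.7-fold higher number from compound 1 to compound 2 (0.43 log units; beyond the scatter) and a 9.4-fold lower number from compound 1 to compound 3 (0.97 log units; beyond the scatter), both beyond the scatter, and they show that 3-bromophenyl is well tolerated while 2-chlorophenyl is not. Since 3,5-dichlorophenyl, with its two chlorines, follows the pattern of 3-bromophenyl with its single bromine rather than that of 2-chlorophenyl, the expectation for compound 4 in this assay is a step within the scatter or at most a small lowering, a 1.2-fold lower number from compound 3 to compound 4 (0.09 log units; within the scatter). Compound 4 is thus estimated at 65 nM, with a range from 25 nM to 200 nM.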

Compound 4, half-maximal effective concentration: 306 nM
Compound 4: middle estimate off by 4.7-fold (0.67 log units), on the low side; measured number outside the range, above it.
By their numbers in this assay, from the lowest: compound 3; then compound 4; then compound 1; then compound 2.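

At the group on the carbonyl carbon in this assay, a second ring halogen does not hold the low number seen with a single bromine: 3,5-dichlorophenyl in place of 3-bromophenyl gives a 3.8-fold higher number from compound 3 to compound 4 (0.58 log units; beyond the scatter), and compound 3 remains the lowest of the four. The 3,5-dichlorophenyl group still improves on the other two groups, with a 6.7-fold lower number from compound 2 to compound 4 (0.82 log units; beyond the scatter) and a 2.5-fold lower number from compound 1 to compound 4 (0.39 log units; beyond the scatter), so compound 4 sits in the middle of the series rather than level with compound 3. No measurement at hand accounts for this step.

The change swaps bromine for chlorine and adds a second halogen together; a 3-chlorophenyl or 3,5-dibromophenyl group would separate the two. Going by these compounds, how an aminophenyl or carboxyphenyl group behaves on this carbonyl carbon remains open.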